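A few compounds are considered here, and "the series" means these few. Any claim that something is new, unique, unknown or untested is made for them only; others in the source may bear on it.

In an ADME assay on Vero cells (Chlorocebus sabaeus) for cytotoxicity (a lower number here means that less compound is tolerated, a higher number that more compound is tolerated), compound 2 (`CCCCNc1[nH]c2c(F)cc(F)cc2c(=O)c1C(C)=O`) gives > 25000 nM as its reading, which is a limit of the assay and not a number. Compound 1 (`CC(=O)c1c(N2CCCCC2)[nH]c2c(F)cc(F)cc2c1=O`) gives > 25000 nM as its reading, again a limit. Compound 3 (`CC(=O)c1c(NCc2ccc(F)cc2F)[nH]c2c(F)cc(F)cc2c1=O`) gives > 25000 nM as its reading, also a limit. Compound 2 therefore stands with the other two measured compounds (the limit of > 25000 nM in this assay, at which 3 of the 3 values shown sit).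

Compound 4 (`COc1ccc(Nc2[nH]c3c(F)cc(F)cc3c(=O)c2C(C)=O)cc1`) differs from compound 2 by 4-methoxyphenyl in place of butyl on a nitrogen on an aromatic ring. Among the measured compounds shown here, two measured steps bear on this change (a step that the two limits leave unreadable from compound 1 to compound 2) and (a step that the two limits leave unreadable from compound 2 to compound 3). The second also brings in an aromatic ring, but neither step has a size that can be read. No step beyond the scatter is therefore expected in this assay, in either direction, and a further limit is the likeliest report. The expected step is a number no higher from compound 2 to compound 4 (the limit leaves the size open) on this estimate. For compound 4 the estimated value is 25000 nM with an expected range from 10000 nM to 50000 nM in this assay when a number is reported.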

Compound 4, half-maximal cytotoxic concentration: > 25000 nM
Compound 4: only a limit was reported (the forecaster's own chance of this, stated with the estimate: 75%); the middle value sits exactly at the limit.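

Compound 2 and compound 4 are both reported in this assay only as limits, so no step can be read between them: the limit of > 25000 nM in this assay, at which 4 of the 4 values shown sit.

The compounds shown leave open the concentration at which any of them reaches half-maximal cytotoxicity in this assay, and whether their groups differ at all there.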